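Trifluoromethyl in Place of Trifluoromethoxy: Cytotoxicity Expected Unchanged

The compounds below may be only part of what the source reports. "The series", "measured", "known", "first", "only" and "open" are said of these compounds alone.

compound 1 `O=[N+]([O-])c1cn2c(n1)OCC(COc1ccc(-c3ccc(OC(F)(F)F)cc3)nc1)C2` — > 10 ug/mL
compound 2 `O=[N+]([O-])c1cn2c(n1)SC(COCc1ccc(OCc3ccccc3)cc1)C2` — > 10 ug/mL

Of the compounds shown here, two have so far been tested in an ADME assay on L929 cells (Mus musculus) for cytotoxicity; on this read-out higher numbers stand for weaker inhibition and lower numbers for stronger inhibition. For compound 1 the read-out is only a limit of the assay, > 10 ug/mL. For compound 2 the read-out is likewise a limit, > 10 ug/mL. For the measured compounds named here, compound 1 therefore stands at the limit of > 10 ug/mL in this assay, at which 2 of the 2 values shown sit, and no number separates it from the only other measured compound; the two values show nothing more than that neither reached the read-out within the tested range.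

Compound 3 `O=[N+]([O-])c1cn2c(n1)OCC(COc1ccc(-c3ccc(C(F)(F)F)cc3)nc1)C2` differs from compound 1 in a single place: trifluoromethyl in place of trifluoromethoxy on an aromatic carbon. Going by the values given here, no measured pair of compounds differs in just this way, so there is no measured step to lean on for the change. In this assay a step that the limit leaves unreadable from compound 1 to compound 3 is expected, which is to say none beyond the scatter, since compound 1 already sits at the limit of > 10 ug/mL in this assay, at which 2 of the 2 values shown sit. Compound 3 is expected to give about 15 ug/mL, within a range from 8 ug/mL to 40 ug/mL, and most probably again only a limit rather than a number.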

Compound 3, half-maximal inhibitory concentration: > 10 ug/mL
Compound 3: a limit, no number (the forecaster's own chance of this, stated with the estimate: 80%); the middle value does not contradict the limit.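

In this assay compound 3 gives > 10 ug/mL as a limit of the assay, not a number. For the compounds shown here, compound 1 and compound 3 both sit at such a limit, so no step between them can be read. The compounds shown leave open whether trifluoromethyl in place of trifluoromethoxy alters cytotoxicity at all, and at what concentration any of them would reach the half-maximal read-out.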